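The source may hold more compounds than are shown below. What is called first, only, known or untested is meant among the compounds shown, and "the series" means these compounds.

Compound 1 `COCC(C)Oc1cccc2ccc(N)nc12` has been tested in an assay on cells with melanin-concentrating hormone receptor 1 (Homo sapiens) as the target, read by radioligand binding (on this read-out lower numbers stand for stronger inhibition and higher numbers for weaker inhibition), where compound 1 gives 606 nM. Of the two plain numbers available, compound 1 holds the higher one, since compound 2 `CCC(C)COc1cccc2ccc(N)nc12` gives 36 nM. Compound 3 `CC#CCCOc1cccc2ccc(N)nc12` reaches only a limit of this assay, > 2000 nM, which is not a number. Compound 4 `CC(C)OCCOc1cccc2ccc(N)nc12` differs from compound 1 by 2-isopropoxyethyl in place of 1-(methoxymethyl)ethyl on an oxygen on an aromatic ring. The measured steps concern other replacements: the step of a 17-fold lower number from compound 1 to compound 2 (1.23 log units; beyond the scatter) was large, while the step of an at least 3.3-fold higher number from compound 1 to compound 3 (0.51 log units; beyond the scatter) went the opposite way. Neither matches the change into compound 4, so both bear on it only loosely. Compound 4 is expected to show a small step at most, a 1.5-fold lower number from compound 1 to compound 4 (0.18 log units; within the scatter). Compound 4 is therefore estimated at 400 nM, within a range from 150 nM to 1200 nM.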

Compound 4, half-maximal inhibitory concentration: > 2000 nM
Compound 4: only a limit was reported (the forecaster's own chance of this, stated with the estimate: 10%); middle value at least 5.0-fold (0.69 log units) from the limit.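

Putting 2-isopropoxyethyl on this oxygen weakens binding compared with 1-(methoxymethyl)ethyl, with an at least 3.3-fold higher number from compound 1 to compound 4 (0.51 log units; beyond the scatter) and, against the 2-methylbutyl chain, an at least 55-fold higher number from compound 2 to compound 4 (1.74 log units; beyond the scatter). Both oxygen-bearing chains carry one hydrogen-bond acceptor and no ring, so that count alone does not hold the value at this position. Compound 4 reaches only a limit, which is not a number: the limit of > 2000 nM in this assay, at which 2 of the 4 values shown sit.

As far as these compounds go, how far compound 4 lies past that limit stays open, and the step between compound 3 and compound 4 cannot be read. From the compounds shown here alone, whether an amine or a longer plain alkyl chain on this oxygen would bind as well as the 2-methylbutyl chain also stays open.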